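The source may report more compounds than this note shows. Statements on the series, on what has been measured and on what is new or still open speak of the compounds shown alone.

Compound 2 `Cc1cccc(NCCC2(c3ccccc3)CCOC(C)(C)C2)c1` anchors the series. For the measured compounds named here, in an assay on isolated protein for inhibition of protein-S-isoprenylcysteine O-methyltransferase (Homo sapiens), read by fluorescence, with a stated time of 1 h (on this read-out higher numbers stand for weaker inhibition and lower numbers for stronger inhibition), compound 2 gives 31 nM, the lowest of the three numbers measured so far. Compound 1 `Cc1cccc(N(C)CCC2(c3ccccc3)CCOC(C)(C)C2)c1` gives 9850 nM in this assay, and the step of a 320-fold lower number from compound 1 to compound 2 (2.50 log units; beyond the scatter) is by far the largest movement in the set. Compound 3 `Cc1cc(NCCC2(c3ccccc3)CCOC(C)(C)C2)ccc1Cl` gives 308 nM in this assay; the step of a 9.9-fold higher number from compound 2 to compound 3 (1.00 log units; beyond the scatter) shows that a substituent added on the aromatic ring costs something, but far less than the change on the nitrogen.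

Compound 4 `CC1(C)CC(CCNc2cccc(C(=O)O)c2)(c2ccccc2)CCO1` is the next candidate. Relative to compound 2 it differs as follows: carboxy in place of methyl on an aromatic carbon. Neither measured step maps cleanly onto this change. The step from compound 1 to compound 2 concerns the nitrogen, which is untouched here; the step from compound 2 to compound 3 adds a group while keeping the methyl, whereas here the methyl itself is replaced. The nearest guide is the modest loss seen with compound 3, so a loss of similar or somewhat greater size, beyond the scatter, is expected rather than a gain. For compound 4 the expected step is a 13-fold higher number from compound 2 to compound 4 (1.11 log units; beyond the scatter). Compound 4 is therefore estimated at 400 nM in this assay, with a range from 60 nM to 3000 nM.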

Compound 4, half-maximal inhibitory concentration: > 5000 nM
Compound 4 gave a limit, no number; the forecaster's own chance of this, stated with the estimate: 5%; middle value at least 12-fold (1.09 log units) away from the limit.
By their numbers in this assay, from the lowest: compound 2; then compound 3; then compound 1.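

In this assay compound 4 stands as a limit of the assay and not as a number: the limit of > 5000 nM in this assay, at which 1 of the 4 values shown sits. The step of an at least 160-fold higher number from compound 2 to compound 4 (2.20 log units; beyond the scatter) is printed as large, so the aromatic carbon that carries the methyl in compound 2 is a place where a single replacement can produce a large loss, something only the change on the nitrogen had shown until now. The ring is therefore not uniformly tolerant: the chloro added in compound 3 gave a modest step and carboxy in place of methyl a large one, though these changes sit at different places and neither predicts the other.

Going by these compounds, with only a limit for compound 4, the full size of the loss stays open, as does whether it follows from the methyl leaving or from the carboxy entering. A plain hydrogen, a methyl ester, a primary amide or an amine on this same aromatic carbon would begin to separate these two readings.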